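Piperazine nitrogen substituent series: compound 3 to compound 4

The compounds below may be only part of what the source reports. "The series", "measured", "known", "first", "only" and "open" are said of these compounds alone.

Compound 3 `Nc1ccccc1NC(=O)c1ccc(CSC(=S)N2CCN(c3cccnc3)CC2)cc1` gives the highest of the three numbers measured in a functional assay on MGC-803 cells (Homo sapiens) for antiproliferative activity, read by CCK-8 assay, with a stated time of 72 h, tested at 8 uM (a higher number here means a stronger effect of the compound at the concentration tested, a lower number a weaker effect), at 76.9%. Compound 1 `Nc1ccccc1NC(=O)c1ccc(CSC(=S)N2CCN(Cc3ccccn3)CC2)cc1` gives 65.2%, and compound 2 `Nc1ccccc1NC(=O)c1ccc(CSC(=S)N2CCN(c3ccc(Cl)cc3)CC2)cc1` gives 17.2%, with a number 48 percentage points lower from compound 1 to compound 2 (beyond the scatter) and a number 59.7 percentage points higher from compound 2 to compound 3 (beyond the scatter). Compound 4 `Nc1ccccc1NC(=O)c1ccc(CSC(=S)N2CCN(c3ccc(F)cc3)CC2)cc1` differs from compound 3 by 4-fluorophenyl in place of pyridin-3-yl on an amine nitrogen in a ring. The step from compound 2 to compound 3 bears most on this change: compound 2 carries 4-chlorophenyl on the same amine nitrogen in a ring, and that step was large, as was the drop from compound 1 to compound 2. For compound 4 a large fall in this assay is therefore expected, a number 51.9 percentage points lower from compound 3 to compound 4 (beyond the scatter). For compound 4 the estimate in this assay is 25%, with a range from 10% to 50%.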

Compound 4, a percentage reported as inhibition, at one concentration (the size of the read-out at that concentration, not a potency): 48.7%
Beside the measured number, compound 4's estimate is 23.7 percentage points below it, within the range that was stated.
By their numbers in this assay, from the lowest: compound 2; then compound 4; then compound 1; then compound 3.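

In this assay, the identity of the halogen on the phenyl ring at this amine nitrogen matters: fluoro in place of chloro gives a number 31.5 percentage points higher from compound 2 to compound 4 (beyond the scatter), so a phenyl group here does not by itself fix the number at the low end. Even so, 4-fluorophenyl stays short of both groups that carry pyridine, with a number 28.2 percentage points lower from compound 3 to compound 4 (beyond the scatter) and a number 16.5 percentage points lower from compound 1 to compound 4 (beyond the scatter). No measurement at hand accounts for these steps.

As far as these compounds go, whether an unsubstituted phenyl or a 4-methoxyphenyl continues the order from chloro to fluoro remains open. So does whether pyridin-4-yl or pyrimidin-5-yl on this nitrogen keeps the higher numbers.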